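Methyl on the carbon-only ring of compound 3

This account rests on a few compounds, and the source may have more. Where it says the series, first, only, none or still open, it means among the compounds named here.

Compound 1 `Cc1ccc2c(=O)n(C)c3c(c2c1)CCOc1ccccc1-3`, compound 2 `COc1ccc(Cn2c3c(c4ccccc4c2=O)CCOc2ccccc2-3)cc1` and compound 3 `COCOc1ccccc1-c1cc2ccccc2c(=O)[nH]1` have been tested in an assay on isolated protein for inhibition of DNA topoisomerase 1 (Homo sapiens), tested at 100 uM; a higher number here means more inhibition at the concentration tested (going by the name of the read-out), a lower number less inhibition. Compound 2 gives 94.5%, the only entry in the set that comes with a number. Compound 1 is recorded as "not active" (no number reported), without a number. Compound 3 likewise stands as "not active" (no number reported), so there is no single number for it and it shares this with one further entry. Compound 4 `COCOc1ccccc1-c1cc2cc(C)ccc2c(=O)[nH]1` is not yet measured. Relative to compound 3 it carries methyl in place of hydrogen on an aromatic carbon, nothing else changing. Among the compounds with values here, no step between measured compounds exists to gauge what this change does, and compound 1, which also carries a methyl on its core, reports no number either. The expectation for compound 4 in this assay is therefore a small shift at most, none beyond the scatter, with a fair chance that again only a limit is returned. Compound 4 is estimated at 8%, with a range from 0% to 30%.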

Compound 4, a percentage reported as inhibition, at one concentration (the size of the read-out at that concentration, not a potency): "not active" (no number reported)
Compound 4: no number reported; no gap can be computed for the estimate.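

No new step can be read between compound 3 and compound 4: in this assay compound 3 gives "not active" (no number reported) and compound 4 gives "not active" (no number reported) with no number on either side. As far as these compounds go, what methyl in place of hydrogen does to inhibition remains open. No evidence bears on this result.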